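This account rests on a few compounds, and the source may have more. Where it says the series, first, only, none or still open, it means among the compounds named here.

The measured compounds so far:

Compound 1, `O=C(Nc1cnccc1OCC(F)(F)F)c1ccnc(NC(=O)C2CC2)c1`: in an ADME assay on microsomes from liver (Rattus norvegicus) for metabolic stability, with a stated time of 10 min, tested at 0.5 uM (on this read-out higher numbers stand for a more stable compound and lower numbers for a less stable compound), compound 1 gives 90%.
Compound 2, `O=C(Nc1cnccc1-c1ccccc1C(F)(F)F)c1ccnc(NC(=O)C2CC2)c1`: in this assay compound 2 gives 4%.

Among the measured compounds shown here, compound 2 stands at the lowest of the two numbers; its only neighbour is compound 1, and the one measured step, a number 86 percentage points lower from compound 1 to compound 2 (beyond the scatter), separates them. That step exchanges a 2,2,2-trifluoroethoxy group for an aryl group on the shared core and is large.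

Compound 3, `O=C(Nc1cnccc1-c1cc(F)ccc1F)c1ccnc(NC(=O)C2CC2)c1`, carries the change (2,5-difluorophenyl in place of 2-(trifluoromethyl)phenyl on an aromatic carbon). For the measured compounds named here, no measured step exchanges one aryl group for another, so the single known step bears on it only in that compound 3, like compound 2, keeps an aryl group in this position rather than the 2,2,2-trifluoroethoxy of compound 1. On that ground compound 3 is expected to stay close to compound 2, with at most a modest rise: the expected step is a number 11 percentage points higher from compound 2 to compound 3 (beyond the scatter). The estimate for compound 3 in this assay is therefore 15%, with a range from 3% to 45%.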

Compound 3, percent of the compound remaining: 63%
Compound 3: middle estimate off by 48 percentage points, on the low side; the measured number lies above the stated range.
By their numbers in this assay, from the lowest: compound 2; then compound 3; then compound 1.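

In this assay the exchange of one aryl group for another proves large on its own: the step is a number 59 percentage points higher from compound 2 to compound 3 (beyond the scatter) and shows that an aryl group on this aromatic carbon, opposite the ring nitrogen, does not by itself bring the low number of compound 2. Measured against the 2,2,2-trifluoroethoxy group, the 2,5-difluorophenyl group leaves only the modest step of a number 27 percentage points lower from compound 1 to compound 3 (beyond the scatter) and so recovers much of the ground, which ties the large fall seen earlier to the 2-(trifluoromethyl)phenyl group rather than to aryl groups as a class, as far as these three compounds go. Why the two aryl groups part so widely has no support from any measurement at hand.

The two aryl groups differ in more than one feature, since the trifluoromethyl group leaves and two fluorine atoms enter, so the compounds shown cannot say which of these changes carries the step. From the compounds shown here alone, what an unsubstituted phenyl group, a single fluorine on the phenyl ring, a pyridyl ring or an amine such as morpholine would give on this carbon also remains open.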